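A few compounds are considered here, and "the series" means these few. Any claim that something is new, unique, unknown or untested is made for them only; others in the source may bear on it.

Compound 1 `CCCCc1nc(C)c(CC(=O)O)c(=O)n1Cc1ccc(-c2ccccc2-c2nnn[nH]2)cc1`: 0.13 mg/kg
Compound 2 `CCCCc1nc(C)c(CC(=O)N2CCCC2)c(=O)n1Cc1ccc(-c2ccccc2-c2nnn[nH]2)cc1`: 0.056 mg/kg
Compound 3 `CCCCc1nc(C)c(CC(=S)N(CC)CC)c(=O)n1Cc1ccc(-c2ccccc2-c2nnn[nH]2)cc1`: 0.023 mg/kg

In an in vivo functional assay on the whole organism for inhibition, with Rattus norvegicus as the target (a higher number here means that more compound is needed for the effect, a lower number that less compound is needed), compound 3 gives the lowest of the three numbers, at 0.023 mg/kg. Compound 4 `CCCCc1nc(C)c(CC(=S)N2CCCCCC2)c(=O)n1Cc1ccc(-c2ccccc2-c2nnn[nH]2)cc1` carries azepan-1-yl in place of diethylamino on a thiocarbonyl carbon.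

Within the data shown here, no measured step isolates this swap. The nearest is a 2.4-fold lower number from compound 2 to compound 3 (0.39 log units; beyond the scatter), but it also changes the carbonyl to a thiocarbonyl. a 2.3-fold lower number from compound 1 to compound 2 (0.37 log units; beyond the scatter) and a 5.7-fold lower number from compound 1 to compound 3 (0.75 log units; beyond the scatter) both replace the acid hydroxy, and each stayed modest. A small change is therefore expected, with no clear direction. The expected step is a 1.3-fold higher number from compound 3 to compound 4 (0.12 log units; within the scatter), probably not beyond the scatter. For compound 4 the estimate is 0.03 mg/kg, with an expected range from 0.01 mg/kg to 0.09 mg/kg.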

Compound 4, dose for half-maximal effect: 0.034 mg/kg
Compound 4: middle estimate off by 1.1-fold (0.05 log units), on the low side; the range from low to high includes it.
By their numbers in this assay, from the lowest: compounds 3, 4 and 2 (each within the scatter of the next, the first and the last beyond it); then compound 1.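

The change from diethylamino to azepan-1-yl on the thiocarbonyl carbon, a 1.5-fold higher number from compound 3 to compound 4 (0.17 log units; within the scatter), shows that in this assay this position accepts a seven-membered ring as well as an open chain. The azepan-1-yl thiocarbonyl group cannot be told apart from the pyrrolidin-1-yl carbonyl group (a 1.6-fold lower number from compound 2 to compound 4 (0.22 log units; within the scatter)), yet it stays clearly separate from the free acid (a 3.8-fold lower number from compound 1 to compound 4 (0.58 log units; beyond the scatter)). Nothing available explains these results.

Still open, going by these compounds, is how pyrrolidin-1-yl or morpholin-4-yl would fare on the thiocarbonyl carbon. So is how azepan-1-yl would fare on a carbonyl carbon, which would isolate the sulfur-for-oxygen change.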